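Serine phosphate series: aryl ether substituent and intrinsic activity

The compounds below may be only part of what the source reports. "The series", "measured", "known", "first", "only" and "open" are said of these compounds alone.

Three compounds of the shared core have a number in an assay on cells for activation of probable G-protein coupled receptor 34 (Mus musculus), with a stated time of 1 h; a lower number here means a smaller maximal response, a higher number a larger maximal response. Compound 1 `N[C@@H](COP(=O)(O)OCCCOC(=O)CCc1ccccc1OCc1cccc(Oc2ccccc2Cl)c1)C(=O)O` gives 0.069; compound 2 `N[C@@H](COP(=O)(O)OCCCOC(=O)CCc1ccccc1OCc1cccc(Oc2cccc(Cl)c2)c1)C(=O)O` gives 0.53; compound 3 `N[C@@H](COP(=O)(O)OCCCOC(=O)CCc1ccccc1OCc1cccc(Oc2ccc(Cl)cc2)c1)C(=O)O` gives 0.76. Compound 3 stands highest of the three: the step a number 0.69 higher from compound 1 to compound 3 (beyond the scatter) is large, the step a number 0.23 higher from compound 2 to compound 3 (beyond the scatter) is modest, and both lie beyond the scatter, as does the step a number 0.46 higher from compound 1 to compound 2 (beyond the scatter). All three measured steps move a chloro from one position to another on the phenyl attached through an oxygen on an aromatic ring.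

Compound 4 `Cc1ccccc1-c1ccc(Oc2cccc(COc3ccccc3CCC(=O)OCCCOP(=O)(O)OC[C@H](N)C(=O)O)c2)cc1` is the next compound, differing from compound 3 as follows: 2-methylphenyl in place of chloro on an aromatic carbon. Here the chloro leaves altogether and 2-methylphenyl enters at the same place. Among the compounds with values here, no measured step swaps the chloro for another group; the three steps only show that the position of a chloro on that ring matters strongly, not what a larger group does in its place. The expectation therefore rests on compound 3 alone, with a wide range. Compound 4 is expected to stay near compound 3, with an estimated step a number 0.060 lower from compound 3 to compound 4 (within the scatter) not beyond the scatter. Compound 4 is estimated at 0.7 in this assay, in a range from 0.35 to 1.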

Compound 4, intrinsic activity: the largest response reached, as a fraction of the reference agonist's: 0.94
Compound 4: the middle estimate sits 0.24 below what was measured, within the range that was stated.
By their numbers in this assay, from the lowest: compound 1; then compound 2; then compound 3; then compound 4.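

In this assay, 2-methylphenyl in place of chloro on this aromatic carbon, para to a large group, gives a number 0.18 higher from compound 3 to compound 4 (beyond the scatter) and so shows that the place accepts far more than a single chlorine: 7 heavy atoms and a six-membered aromatic ring enter for 1 heavy atom, and the maximal response rises rather than falls. Within the data shown here, the earlier steps only moved a chloro around the ring, so this is the first step that changes the group itself rather than its position, and it shows that the chloro is not needed for a high maximal response in this core. No measurement at hand gives a reason for the rise.

The compounds shown leave open whether the rise belongs to the added ring as such or to its methyl, a question that an unsubstituted phenyl at the same place would address. They also leave open how a group without an aromatic ring would compare there, such as a morpholine, a carboxylic acid or a longer alkyl chain like n-butyl.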